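Compound 3: Expected Clearance After a Ring Swap

The source may hold more compounds than are shown below. What is called first, only, known or untested is meant among the compounds shown, and "the series" means these compounds.

Of the compounds shown here, two have been measured in an ADME assay (liver) for metabolic stability, with Liver microsome (Homo sapiens) as the target, using microsomes and NADPH, with a stated time of 30 min, tested at 1 uM; on this read-out higher numbers stand for fast clearance and lower numbers for slow clearance. Compound 1 `Nc1ccc(S(=O)(=O)N2CCN(c3ncc(C(O)(C(F)(F)F)C(F)(F)F)cc3C#CC3CC3)CC2)cn1` gives only an assay limit in this assay, < 14 mL.min-1.g-1, so its true number is not known. Compound 2 `Cc1csc(-c2cc(C(O)(C(F)(F)F)C(F)(F)F)cnc2N2CCN(S(=O)(=O)c3ccc(N)nc3)CC2)c1` gives 29 mL.min-1.g-1 in this assay. Going by the values given here, the step of an at least 2.0-fold higher number from compound 1 to compound 2 (0.31 log units; beyond the scatter) is therefore at least modest, and compound 2 stands as the only compound with a definite number, the other value being a limit (the limit of < 14 mL.min-1.g-1 in this assay, at which 1 of the 2 values shown sits).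

Compound 3 `Nc1ccc(S(=O)(=O)N2CCN(c3ncc(C(O)(C(F)(F)F)C(F)(F)F)cc3-c3ccc4sccc4c3)CC2)cn1` differs from compound 2 in one place: 1-benzothiophen-5-yl in place of 4-methylthiophen-2-yl on an aromatic carbon, on an aromatic carbon of a six-membered aromatic ring with one nitrogen, ortho to a large group, two atoms from the ring nitrogen, and meta to the 2,2,2-trifluoro-1-hydroxy-1-(trifluoromethyl)ethyl group. Among the compounds with values here, the only measured step touching this same position is the one from compound 1 to compound 2, where exchanging the group at this site moved the clearance by a modest amount. A change of similar size is expected here, with no clear direction, so compound 3 is estimated at 38 mL.min-1.g-1 in this assay, between 18 mL.min-1.g-1 and 80 mL.min-1.g-1, a step of a 1.3-fold higher number from compound 2 to compound 3 (0.12 log units; within the scatter) that is expected to stay near the scatter.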

Compound 3, intrinsic clearance in microsomes: 48 mL.min-1.g-1
Estimate against measurement, compound 3: 1.3-fold (0.10 log units) below; the range from low to high includes it.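

Exchanging 4-methylthiophen-2-yl for 1-benzothiophen-5-yl, which brings in a six-membered aromatic ring of carbon only and takes the group from 6 to 9 heavy atoms, gives a 1.7-fold higher number from compound 2 to compound 3 (0.22 log units; within the scatter) in this assay, so on this read-out these two groups cannot be told apart at this position. The exchange of 2-cyclopropylethynyl for 1-benzothiophen-5-yl gives an at least 3.4-fold higher number from compound 1 to compound 3 (0.53 log units; beyond the scatter), which lies beyond the scatter, as does the earlier step of an at least 2.0-fold higher number from compound 1 to compound 2 (0.31 log units; beyond the scatter), so both compounds with an aromatic ring here stand apart from the compound with the 2-cyclopropylethynyl group. Compound 1 gives only an assay limit and not a number, so the full size of both steps stays unknown: the limit of < 14 mL.min-1.g-1 in this assay, at which 1 of the 3 values shown sits.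

The compounds shown leave open how a plain phenyl ring, an amine or a carboxylic acid at this position would behave on this read-out. They also leave open which part of the 2-cyclopropylethynyl group goes with the limit seen for compound 1, the triple bond or the cyclopropyl ring.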